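The source may report more compounds than this note shows. Statements on the series, on what has been measured and on what is new or still open speak of the compounds shown alone.

Working notes on a small set read in a functional assay on Hs 683 cells (Homo sapiens) for cytotoxicity, read by MTT assay, with a stated time of 72 h; on this read-out lower numbers stand for stronger inhibition and higher numbers for weaker inhibition. Compound 1 `Cc1ccc2[nH]c(-c3ccc[nH]3)c(C3CC(=O)NC3=O)c2c1` gives 8000 nM and stands at the lowest of the two numbers on hand. Compound 2 `COc1ccc2[nH]c3c(c4c(n5cccc35)C(=O)N(C)C4=O)c2c1` gives 72000 nM, a higher number than compound 1 by a gap beyond the scatter. Compound 3 `Cc1ccc2[nH]c(-n3cccn3)cc2c1` returns only a limit, > 100000 nM, which marks an edge of this assay rather than a number: the limit of > 100000 nM in this assay, at which 1 of the 3 values shown sits.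

Compound 4 `O=C1CC(c2c(-c3ccc[nH]3)[nH]c3ccccc23)C(=O)N1` has not been measured. Against compound 1 it shows a single small change: hydrogen in place of methyl on an aromatic carbon. For the measured compounds named here, no pair of measured compounds in the set differs by such a change, so there is no measured step of this kind to lean on. The removal of one carbon from the six-membered aromatic ring is expected to move the number little, with no clear direction; the step of a 1.4-fold higher number from compound 1 to compound 4 (0.14 log units; within the scatter) is expected to lie within the scatter of repeated measurements. Compound 4 is therefore estimated at 11000 nM, with a range from 4000 nM to 35000 nM.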

Compound 4, half-maximal inhibitory concentration: 25000 nM
Beside the measured number, compound 4's estimate is 2.3-fold (0.36 log units) below it; low and high end bracket the measured number.
By their numbers in this assay, from the lowest: compound 1; then compound 4; then compound 2. At a limit, above all of these: compound 3.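

In this assay, for the compounds shown here, the change gives the first measured step at this position: a 3.1-fold higher number from compound 1 to compound 4 (0.49 log units; beyond the scatter), so hydrogen in place of methyl on this aromatic carbon moves the number up, modestly but beyond the scatter. The earlier compounds shown here differ from one another in more than one place and could not single out this carbon. Nothing on hand bears on the cause of this step.

Only methyl and hydrogen are shown at this carbon, so it stays open whether chlorine, an amine, a carboxylic acid or a longer chain would give a lower or a higher number. On these data alone, with a single pair, it also stays open whether the step would hold on a core other than the one shared by these two compounds.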